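Ring closure on the amino acid: compound 1 to compound 3

The source may hold more compounds than are shown below. What is called first, only, known or untested is meant among the compounds shown, and "the series" means these compounds.

Measured compounds:
- Compound 1, `CC(C)(NC(=O)c1cccc2c(Br)c(-c3ccc(Cl)cc3)oc12)C(=O)O`, 1760 nM
- Compound 2, `CN(C(=O)c1cc(F)cc2cc(-c3ccc(Cl)cc3)oc12)C(C)(C)C(=O)O`, 1970 nM

In an assay on isolated protein for inhibition of endoplasmic reticulum aminopeptidase 1 (Homo sapiens), with stated times of 15 min and 20 min (a higher number here means a weaker inhibitor, a lower number a stronger inhibitor), compound 1 gives 1760 nM. Compound 2 gives 1970 nM in this assay. The two numbers lie within the usual scatter of repeated measurements, so neither compound can be called the stronger inhibitor on these data.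

Compound 3, `O=C(NC1(C(=O)O)CCCCC1)c1cccc2c(Br)c(-c3ccc(Cl)cc3)oc12`, has not yet been measured in this assay. It differs from compound 1 in one place: 1-carboxycyclohexyl in place of 1-carboxy-1-methylethyl on an amide-type nitrogen. Among the measured compounds shown here, no step between measured compounds tells what such a change does here, so the expectation rests only on compound 1 and the change itself. A step of about a 1.5-fold lower number from compound 1 to compound 3 (0.17 log units; within the scatter) is expected, a small one that may well fall within the scatter. Compound 3 is estimated to give 1200 nM in this assay, with a range from 400 nM to 3600 nM.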

Compound 3, half-maximal inhibitory concentration: 151 nM
Compound 3: the middle estimate sits 7.9-fold (0.90 log units) above what was measured; the whole stated range lies above it.
By their numbers in this assay, from the lowest: compound 3; then compounds 1 and 2 (each within the scatter of the next).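

In this assay, the group on the amide-type nitrogen proves to matter a great deal: 1-carboxycyclohexyl in place of 1-carboxy-1-methylethyl gives a 12-fold lower number from compound 1 to compound 3 (1.07 log units; beyond the scatter) with the rest of compound 1 unchanged. Compounds 1 and 2 differ in more than one place and their values lie within the scatter, so they gave no sign that a single change here could move the number this far. Nothing at hand explains the gain.

Going by these compounds, whether the six-membered ring is needed stays open, since one smaller ring, as in 1-carboxycyclopentyl, or an open chain, as in 1-carboxy-1-ethylpropyl, could show how much of the step depends on ring closure. Also open, on these data alone, is whether the same exchange would give a similar step on the core of compound 2.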